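The source may report more compounds than this note shows. Statements on the series, on what has been measured and on what is new or still open speak of the compounds shown alone.

Working notes on the series. All three measured compounds share one core and a sulfur-linked side chain that varies. Compound 1 `CC(C)c1n[nH]c2c(NCc3ccc(-c4ccccn4)cc3)nc(SCC(N)=O)nc12` carries carbamoylmethyl on the sulfur; in a functional assay on HT cells (Homo sapiens) for antiproliferative activity, read by fluorescence, with a stated time of 72 h (on this read-out lower numbers stand for stronger inhibition of growth and higher numbers for weaker inhibition of growth), compound 1 gives 192 nM. Compound 2 `CC(C)c1n[nH]c2c(NCc3ccc(-c4ccccn4)cc3)nc(SC3CCCC3O)nc12` carries 2-hydroxycyclopentyl on the sulfur, and in this assay compound 2 gives 567 nM. Compound 3 `CC(C)c1n[nH]c2c(NCc3ccc(-c4ccccn4)cc3)nc(SCCO)nc12` carries 2-hydroxyethyl on the sulfur; in this assay compound 3 gives 48 nM, the lowest of the three numbers, with compound 1 nearest and compound 2 furthest. The steps run a 4.0-fold lower number from compound 1 to compound 3 (0.60 log units; beyond the scatter), a 12-fold lower number from compound 2 to compound 3 (1.07 log units; beyond the scatter) and a 3.0-fold higher number from compound 1 to compound 2 (0.47 log units; beyond the scatter).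

Compound 4 `CC(=O)NCCSc1nc(NCc2ccc(-c3ccccn3)cc2)c2[nH]nc(C(C)C)c2n1` is not yet measured. It differs from compound 3 by acetamido in place of hydroxy on a saturated chain carbon, two bonds along the chain from a sulfur. Within the data shown here, two measured steps bear on this change: a 4.0-fold lower number from compound 1 to compound 3 (0.60 log units; beyond the scatter) shows that a chain ending in carbamoyl rather than hydroxymethyl gave the higher number, and a 12-fold lower number from compound 2 to compound 3 (1.07 log units; beyond the scatter) shows that the larger hydroxy-bearing group gave the higher number. Compound 4 both lengthens the chain beyond hydroxy and brings in acetamido, so a modest step upward in this assay is expected, a 3.1-fold higher number from compound 3 to compound 4 (0.49 log units; beyond the scatter). Compound 4 is therefore estimated at 150 nM, with a range of 60 nM to 400 nM.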

Compound 4, concentration for 50% growth inhibition: 71 nM
The estimate for compound 4 lay 2.1-fold (0.32 log units) above the measured number; measured number inside the range.
By their numbers in this assay, from the lowest: compounds 3 and 4 (each within the scatter of the next); then compound 1; then compound 2.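

Among these compounds, on the chain of 2-hydroxyethyl on the sulfur, acetamido in place of hydroxy, with 4 heavy atoms entering for 1 leaving, gives no step that can be told from the scatter in this assay (a 1.5-fold higher number from compound 3 to compound 4 (0.17 log units; within the scatter)). The low numbers at this position are therefore not confined to a chain ending in hydroxy, and (2-acetamidoethyl)sulfanyl keeps a clear distance from 2-hydroxycyclopentyl (an 8.0-fold lower number from compound 2 to compound 4 (0.90 log units; beyond the scatter)). A nitrogen-bearing carbonyl group alone does not settle the number, since carbamoylmethyl goes against any such pattern (a 2.7-fold lower number from compound 1 to compound 4 (0.43 log units; beyond the scatter)).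

As far as these compounds go, whether a free amine, a carboxylic acid or a chain longer than 2-acetamidoethyl would stay with compound 3 and compound 4 remains open. Nothing to hand explains why these chains differ.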